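The compounds below may be only part of what the source reports. "The series", "measured", "known", "first", "only" and "open" are said of these compounds alone.

In a functional assay for inhibition, with Homo sapiens as the target (on this read-out higher numbers stand for weaker inhibition and lower numbers for stronger inhibition), compound 1 `COCc1cc(-c2ccccc2)c2ccc(OCc3cccc(C4(O)CCOCC4)c3)cc2c1` gives 4 nM and compound 2 `N#Cc1cc(-c2ccccc2)c2ccc(OCc3cccc(C4(O)CCOCC4)c3)cc2c1` gives 3 nM, while compound 3 `O=C(O)c1cc(-c2ccccc2)c2ccc(OCc3cccc(C4(O)CCOCC4)c3)cc2c1` gives 190 nM as the highest number of the three. Compound 4 `Cn1nnc(-c2cc(-c3ccccc3)c3ccc(OCc4cccc(C5(O)CCOCC5)c4)cc3c2)n1` has 2-methyl-2H-tetrazol-5-yl in place of carboxy on an aromatic carbon. Among the measured compounds shown here, two measured steps bear on this: a 48-fold higher number from compound 1 to compound 3 (1.68 log units; beyond the scatter) and a 63-fold higher number from compound 2 to compound 3 (1.80 log units; beyond the scatter) are both large and both bring carboxy in, while a 1.3-fold lower number from compound 1 to compound 2 (0.12 log units; within the scatter) stays within the scatter. Losing carboxy is therefore expected to give a large step to a lower number in this assay, though no tetrazole has been measured in the series. The expected change is a 32-fold lower number from compound 3 to compound 4 (1.50 log units; beyond the scatter) in this estimate. For compound 4 the estimate is 6 nM with 2 nM to 25 nM as the expected range.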

Compound 4, half-maximal inhibitory concentration: 4 nM
For compound 4 the middle estimate is 1.5-fold (0.18 log units) above the measured one, and the stated range covers the measured number.
By their numbers in this assay, from the lowest: compounds 2, 1 and 4 (each within the scatter of the next); then compound 3.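

In this assay, 2-methyl-2H-tetrazol-5-yl on this aromatic carbon recovers what carboxy loses, with a 48-fold lower number from compound 3 to compound 4 (1.68 log units; beyond the scatter), and it sits level with the smaller groups, with a 1.3-fold higher number from compound 2 to compound 4 (0.12 log units; within the scatter) and no change at the digits printed from compound 1 to compound 4 (within the scatter). A five-membered aromatic ring is therefore tolerated at this position, leaving compound 3 as the only one of the four apart from the rest. Nothing available accounts for carboxy standing alone. Open, from the compounds shown here alone, is whether a primary amide, a methyl ester or an aminomethyl group at this carbon would group with compound 4 or with compound 3. Also open, going by these compounds, is how the tetrazole without its methyl group would read.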